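This account rests on a few compounds, and the source may have more. Where it says the series, first, only, none or still open, it means among the compounds named here.

Measured compounds:
compound 1 `COc1cc(-c2nn(-c3cccc(NC(=O)c4cccc(C(F)(F)F)c4)c3)cc2-c2ccncc2)ccc1Cl`: 2130 nM
compound 2 `O=C(Nc1cccc(-n2cc(-c3ccncc3)c(-c3ccc(Cl)c(O)c3)n2)c1)Nc1cc(C(F)(F)F)cc(C(F)(F)F)c1`: 846 nM

Both compounds were tested in a functional assay on SF-268 cells (Homo sapiens) for inhibition, read by sulforhodamine B assay, with a stated time of 48 h; on this read-out lower numbers stand for stronger inhibition of growth and higher numbers for weaker inhibition of growth. Compound 1 gives 2130 nM, the highest of the two numbers. Its nearest neighbour, compound 2, gives 846 nM, a number lower than that of compound 1 by a gap beyond the usual scatter. Going by the values given here, no step between compounds differing in one place is available here.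

Compound 3 `COc1cc(-c2nn(-c3cccc(NC(=O)c4ccccc4)c3)cc2-c2ccncc2)ccc1Cl` has not yet been measured. It differs from compound 1 by hydrogen in place of trifluoromethyl on an aromatic carbon, so the 3-(trifluoromethyl)phenyl becomes phenyl. Without a measured step of this kind in this series, the expectation rests only on compound 1 itself. The step from compound 1 to compound 3 in this assay is expected to be a 2.3-fold higher number from compound 1 to compound 3 (0.37 log units; beyond the scatter), toward weaker growth inhibition, of a size somewhat beyond the scatter. Compound 3 is estimated at 5000 nM, within a range of 1500 nM to 16000 nM.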

Compound 3, concentration for 50% growth inhibition: 859 nM
For compound 3 the middle estimate is 5.8-fold (0.76 log units) above the measured one; the whole stated range lies above it.
By their numbers in this assay, from the lowest: compounds 2 and 3 (each within the scatter of the next); then compound 1.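

In this assay, going by these compounds alone, the change from 3-(trifluoromethyl)phenyl to phenyl gives a 2.5-fold lower number from compound 1 to compound 3 (0.39 log units; beyond the scatter) and provides the first step that changes a single place. At this meta position, growth inhibition on these cells therefore does not depend on the trifluoromethyl group, and the unsubstituted phenyl does modestly better within this pair. No measurement here gives a reason for this step.

On these data alone, with only hydrogen and trifluoromethyl compared at this position, it remains open how a fluorine, an amine or a carboxylic acid in the same place would behave. Compound 2 differs from compound 1 and compound 3 in more than one place, so it cannot show whether the same change would have a similar effect in its urea setting.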